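Working notes: pyrrole to furan exchange in compound 4

A few compounds are considered here, and "the series" means these few. Any claim that something is new, unique, unknown or untested is made for them only; others in the source may bear on it.

Values measured in a functional assay on SW480 cells (Homo sapiens) for inhibition, read by MTT assay, with a stated time of 72 h (on this read-out lower numbers stand for stronger inhibition of growth and higher numbers for weaker inhibition of growth), so far:
compound 1 `N#C/C(=C\c1ccc(Cl)cc1)C(=O)c1ccc[nH]1`: 34000 nM
compound 2 `N#C/C(=C\c1ccc([N+](=O)[O-])cc1)C(=O)c1c[nH]c2ccccc12`: 42000 nM
compound 3 `N#C/C(=C\c1ccc[nH]1)C(=O)NCc1ccc(Cl)c(Cl)c1`: > 50000 nM

Compound 3 does not give a number at all; its result in this assay is a limit, > 50000 nM, and it stands at the limit of > 50000 nM in this assay, at which 1 of the 3 values shown sits. Compound 1 with 34000 nM and compound 2 with 42000 nM are the two entries with an actual number, both in the weakly inhibiting range, and the gap between them is within the usual scatter, so no order between the two is claimed. Among the measured compounds shown here, no step between two measured compounds that differ in one place exists in this set, so nothing measured tells how large any single change is.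

Compound 4 `N#C/C(=C\c1ccco1)C(=O)NCc1ccc(Cl)c(Cl)c1` differs from compound 3 in one place: furan-2-yl in place of 1H-pyrrol-2-yl on a double-bonded chain carbon bound to a double-bonded chain carbon. With compound 3 resting on a limit, the expectation for compound 4 is a step of no size beyond the scatter, with no clear direction, and a real chance that this assay again reports only a limit. The estimate for compound 4 is 50000 nM, with a range from 20000 nM to 120000 nM. The step this implies from compound 3 to compound 4 is expected to be a number no higher from compound 3 to compound 4 (the limit leaves the size open).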

Compound 4, concentration for 50% growth inhibition: > 50000 nM
Compound 4 was reported as a limit; the forecaster's own chance of this, stated with the estimate: 60%; the middle value sits exactly at the limit.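

In this assay compound 4 gives > 50000 nM, which is a limit and not a number. Compound 3 also rests on a limit, so no step can be read for furan-2-yl in place of 1H-pyrrol-2-yl from compound 3 to compound 4: the limit of > 50000 nM in this assay, at which 2 of the 4 values shown sit. The compounds shown leave open whether these two groups differ at all in this assay.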